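Swapping one five-membered ring for another on compound 3

A few compounds are considered here, and "the series" means these few. Any claim that something is new, unique, unknown or untested is made for them only; others in the source may bear on it.

Compound 3 `Cc1cnsc1-c1ccccc1OCC1=NCCN1` is measured in a functional assay with Alpha-1A adrenergic receptor (Homo sapiens) as the target, read by calcium flux (on this read-out lower numbers stand for smaller maximal responses and higher numbers for larger maximal responses), where compound 3 gives 104%. That is the second highest of the three values: compound 1 `c1csc(-c2ccccc2OCC2=NCCN2)c1` gives 101%, and the step of a number 3 percentage points higher from compound 1 to compound 3 (within the scatter) stays within the scatter, while compound 2 `c1ccc(-c2ncc[nH]2)c(OCC2=NCCN2)c1` gives 122%, and the step of a number 18 percentage points lower from compound 2 to compound 3 (beyond the scatter) goes beyond it. Compound 4 `Cn1nccc1-c1ccccc1OCC1=NCCN1` differs from compound 3 by 1-methyl-1H-pyrazol-5-yl in place of 4-methyl-1,2-thiazol-5-yl on an aromatic carbon. Among the measured compounds shown here, the steps that bear on this change are a number 3 percentage points higher from compound 1 to compound 3 (within the scatter) and a number 18 percentage points lower from compound 2 to compound 3 (beyond the scatter); both earlier swaps of one five-membered aromatic ring with 2 hetero atoms left the maximal response at or above the control. The step is therefore expected to be a number 1 percentage points higher from compound 3 to compound 4 (within the scatter), not beyond the scatter. Compound 4 is estimated at 105%, within 88% to 122%.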

Compound 4, largest response reached (reported as maximum), in percent of the reference or control that the assay uses: 107%
Compound 4: middle estimate off by 2 percentage points, on the low side, within the range that was stated.
By their numbers in this assay, from the lowest: compounds 1, 3 and 4 (each within the scatter of the next); then compound 2.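

In this assay, the step of a number 3 percentage points higher from compound 3 to compound 4 (within the scatter) and the step of a number 6 percentage points higher from compound 1 to compound 4 (within the scatter) both stay within the scatter, so 1-methyl-1H-pyrazol-5-yl joins thiophen-2-yl and 4-methyl-1,2-thiazol-5-yl as a third group at this position that cannot be told apart. Among the compounds shown here, the step of a number 15 percentage points lower from compound 2 to compound 4 (beyond the scatter) goes beyond the scatter, leaving the 1H-imidazol-2-yl of compound 2 as the only group set apart from the other three. No evidence is at hand that accounts for this separation. Still open, from the compounds shown here alone, is whether a pyridine ring or an aminomethyl group on this aromatic carbon would stay with compound 4 or move towards compound 2.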